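A few compounds are considered here, and "the series" means these few. Any claim that something is new, unique, unknown or untested is made for them only; others in the source may bear on it.

In a functional assay on cells (Homo sapiens) for cytotoxicity, read by MTT assay, with a stated time of 24 h (a lower number here means a stronger inhibitor, a higher number a weaker inhibitor), the three measured compounds gave:

Compound 1 `CCCCCCCCCCCCCCNC(=O)[C@H](CO)NCc1ccccc1O`: 75300 nM
Compound 2 `CCCCCCCCCCCCCCNC(=O)[C@H](CO)/N=C/c1ccccc1Cl`: 10300 nM
Compound 3 `CCCCCCCCCCCCCCNC(=O)[C@H](CO)/N=C/c1ccc(O)cc1`: 19300 nM

Compound 2 gives the lowest number of the three, though only the gap to compound 1 is beyond the scatter: a 7.3-fold lower number from compound 1 to compound 2 (0.86 log units; beyond the scatter). By contrast the pair a 1.9-fold higher number from compound 2 to compound 3 (0.27 log units; within the scatter) lies within the scatter, so compound 2 and compound 3 cannot be told apart.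

Compound 4 `CCCCCCCCCCCCCCNC(=O)[C@H](CO)/N=C/c1ccc(C)cc1` is not yet measured. It differs from compound 2 in one place: 4-methylphenyl in place of 2-chlorophenyl on a carbon with a double bond to nitrogen. Among the compounds with values here, the only measured step that bears on this is the swap of the group on the same carbon, a 1.9-fold higher number from compound 2 to compound 3 (0.27 log units; within the scatter), which stayed within the scatter. A similar outcome is expected here, a 1.4-fold higher number from compound 2 to compound 4 (0.13 log units; within the scatter), with no step beyond the scatter. Compound 4 is therefore estimated at 14000 nM, within a range of 5000 nM to 40000 nM.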

Compound 4, half-maximal inhibitory concentration: 102000 nM
The estimate for compound 4 lay 7.3-fold (0.86 log units) below the measured number, and the stated range ends below it.
By their numbers in this assay, from the lowest: compounds 2 and 3 (each within the scatter of the next); then compounds 1 and 4 (each within the scatter of the next).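

Groups on this carbon are not interchangeable after all: a 9.9-fold higher number from compound 2 to compound 4 (1.00 log units; beyond the scatter), whereas the earlier swap here stayed within the scatter. The group on the ring matters as well, since methyl in place of hydroxy gives a 5.3-fold higher number from compound 3 to compound 4 (0.72 log units; beyond the scatter). Meanwhile, a 1.4-fold higher number from compound 1 to compound 4 (0.13 log units; within the scatter), so those two compounds cannot be told apart.

No measurement shown explains why these steps differ in size. As far as these compounds go, it also remains open whether an amine or a carboxylic acid in place of that methyl would give a number closer to compound 3 or to compound 4.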